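Cyanoguanidine in place of isothiourea on the shared core

A few compounds are considered here, and "the series" means these few. Any claim that something is new, unique, unknown or untested is made for them only; others in the source may bear on it.

Measured compounds:
- compound 1, `CC1(C)Oc2ccc(C#N)cc2[C@@H](/N=C(\NC#N)Sc2ccccc2)[C@@H]1O`: 4900 nM
- compound 2, `CC1(C)Oc2ccc(C#N)cc2[C@@H](NC(=O)Nc2cccnc2)[C@@H]1O`: 500 nM
- compound 3, `COC(=O)c1cn([C@@H]2c3cc(C#N)ccc3OC(C)(C)[C@H]2O)c2ccccc12`: 500 nM

All three were tested in a functional assay (aorta) with Rattus norvegicus as the target; on this read-out higher numbers stand for weaker inhibition and lower numbers for stronger inhibition. Compound 1 gives the highest number of the three, so on this read-out it is the weakest inhibitor; compound 2 and compound 3 both give the same, clearly lower value, and the gap from compound 1 to each of them lies beyond the usual scatter. The three compounds share the same core, and differ only in the group attached to the carbon that carries the hydroxyl-bearing ring.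

Compound 4, `COc1ccc(N/C(=N/[C@@H]2c3cc(C#N)ccc3OC(C)(C)[C@H]2O)NC#N)cc1`, has not yet been measured. It differs from compound 1 in one place: (4-methoxyphenyl)amino in place of phenylsulfanyl on a carbon with a double bond to nitrogen. Within the data shown here, no step between measured compounds of this exact kind is known, so any expectation rests on compound 1 alone and on the fact that both other substituents on this core give lower numbers: compound 2 gives 500 nM and compound 3 gives 500 nM. A move towards a lower number is expected for compound 4, of a size beyond the scatter, about a 6.1-fold lower number from compound 1 to compound 4 (0.79 log units; beyond the scatter). The estimate for compound 4 in this assay is therefore 800 nM, with a range from 200 nM to 4000 nM.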

Compound 4, half-maximal inhibitory concentration: 32500 nM
Compound 4: middle estimate off by 41-fold (1.61 log units), on the low side; the measured number lies above the stated range.
By their numbers in this assay, from the lowest: compounds 2 and 3 (each within the scatter of the next); then compound 1; then compound 4.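

In this assay, among these compounds, putting (4-methoxyphenyl)amino in place of phenylsulfanyl on a carbon with a double bond to nitrogen gives a 6.6-fold higher number from compound 1 to compound 4 (0.82 log units; beyond the scatter), the first step in this set that can be read for a single change. It shows that this carbon is sensitive to what it carries, and that here the change moves the read-out towards weaker inhibition, even though both groups carry a six-membered aromatic ring of carbon only and neither has a net charge. The entering group also brings a hydrogen-bond donor that phenylsulfanyl lacks, but no measurement here explains why the number rises.

This single step swaps the sulfur link for a nitrogen link and adds the methoxy group at the same time, so it cannot say how much of the rise belongs to each. As far as these compounds go, a plain phenylamino group without the methoxy, or a small methylamino group on the same carbon, would help to separate these two parts, and how either would read remains open.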